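The source may report more compounds than this note shows. Statements on the series, on what has been measured and on what is new or still open speak of the compounds shown alone.

Series notes. In a functional assay on QG-56 cells (Homo sapiens) for antiproliferative activity (a lower number here means a stronger inhibitor, a higher number a weaker inhibitor), compound 1 `Cn1cncc1C(O)(c1ccc([N+](=O)[O-])cc1)c1cc2cc([N+](=O)[O-])cc(-c3ccccc3)c2o1` gives 547 nM and compound 3 `Cn1cncc1C(O)(c1ccc(C#N)cc1)c1cc2cc([N+](=O)[O-])cc(-c3ccccc3)c2o1` gives 1480 nM. The change between them is nitro in place of cyano on an aromatic carbon and made a 2.7-fold lower number from compound 3 to compound 1 (0.43 log units; beyond the scatter). Compound 2 `COc1cccc(-c2cc(C#N)cc3cc([C@](N)(c4ccc(C#N)cc4)c4cncn4C)oc23)c1` gives 1.5 nM in this assay, the lowest of the three numbers. The difference between the cores of compound 2 and compound 3 is not broken down here. Compound 4 `COc1cccc(-c2cc([N+](=O)[O-])cc3cc([C@](N)(c4ccc(C#N)cc4)c4cncn4C)oc23)c1` awaits measurement in this assay; against compound 2 the change is nitro in place of cyano on an aromatic carbon, the same kind of change as from compound 3 to compound 1, though the place differs: here the carbon belongs to a ring that is part of a fused or bridged system of two rings, meta to a 3-methoxyphenyl group, meta to a fused ring and para to a fused ring, not para to a large group. A single earlier occurrence is thin ground, so for compound 4 only a step near a 1.5-fold lower number from compound 2 to compound 4 (0.18 log units; within the scatter) is expected, resting on a 2.7-fold lower number from compound 3 to compound 1 (0.43 log units; beyond the scatter). The estimate for compound 4 is 1 nM, between 0.3 nM and 4 nM.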

Compound 4, half-maximal inhibitory concentration: 1.1 nM
The estimate for compound 4 lay 1.1-fold (0.04 log units) below the measured number; the range from low to high includes it.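

In this assay, nitro in place of cyano on the core of compound 2 gives a 1.4-fold lower number from compound 2 to compound 4 (0.13 log units; within the scatter), so the two groups cannot be told apart on this core. The size of the step shows no detectable dependence on the core across the two pairs: the same change on two cores in this assay, a 2.7-fold lower number (0.43 log units; beyond the scatter) from compound 3 to compound 1 and a 1.4-fold lower number (0.13 log units; within the scatter) from compound 2 to compound 4, 2.0-fold (0.30 log units) apart, within the scatter of two such steps. This rests on two pairs only and does not show that the change would behave alike on any further core.

The compounds shown leave open how other groups on this aromatic carbon, such as a carboxylic acid or trifluoromethyl, would read. No pair shown isolates any other single difference between the two cores, so what separates them remains unresolved.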